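Amide variation on a shared dimethoxy core

A few compounds are considered here, and "the series" means these few. Any claim that something is new, unique, unknown or untested is made for them only; others in the source may bear on it.

The series holds three measured amides on one core: compound 1 `COc1cc2c(cc1OC)C(CC(=O)N(C)C)CC2`, compound 2 `CCN(CC)C(=O)CC1CCc2cc(OC)c(OC)cc21` and compound 3 `CCCNC(=O)CC1CCc2cc(OC)c(OC)cc21`. In a functional assay on the whole organism (strain Wistar) for inhibition, with Rattus norvegicus as the target, read by paw edema, with stated times of 60 min and 6 h, at a dose of 100 mg/kg by the oral route (a lower number here means less inhibition, a higher number more inhibition at the dose given (going by the name of the read-out)), compound 1 gives 33.3%, compound 2 gives 31.5% and compound 3 gives 22.2%; compound 2 lies within the scatter of both others, so no order among the three can be read. Going by the values given here, the steps of a number 1.8 percentage points lower from compound 1 to compound 2 (within the scatter) and a number 9.3 percentage points lower from compound 2 to compound 3 (within the scatter) show that changing the amide substituent moves the number little, while a number 11.1 percentage points lower from compound 1 to compound 3 (beyond the scatter) is the only change beyond the scatter. Compound 4 `COc1cc2c(cc1OC)C(CC(=O)N1CCOCC1)CC2` differs from compound 2 by morpholin-4-yl in place of diethylamino on a carbonyl carbon. A tertiary amide is kept, so the expected step of a number 1.5 percentage points lower from compound 2 to compound 4 (within the scatter) is none beyond the scatter. Compound 4 is estimated at 30%, range 18% to 42%.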

Compound 4, a percentage reported as inhibition, in the whole organism at one dose (the size of the read-out at that dose, not a potency): 14.8%
Compound 4: the middle estimate sits 15.2 percentage points above what was measured, and the stated range ends above it.
By their numbers in this assay, from the lowest: compounds 4, 3, 2 and 1 (each within the scatter of the next, the first and the last beyond it).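

In this assay, keeping a tertiary amide on a carbonyl carbon does not keep the number: morpholin-4-yl gives a number 16.7 percentage points lower from compound 2 to compound 4 (beyond the scatter) and a number 18.5 percentage points lower from compound 1 to compound 4 (beyond the scatter). So this position responds to the choice of tertiary amide, which the dimethylamino and diethylamino pair did not show. The third step, a number 7.4 percentage points lower from compound 3 to compound 4 (within the scatter), leaves the propylamino and morpholin-4-yl amides unordered. No measurement on these compounds accounts for the loss. Still open, as far as these compounds go, is whether the ring itself or its oxygen goes with the lower number; a piperidin-1-yl amide on the same carbonyl carbon would separate the two.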